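Replacing an Octyl Chain While Keeping the Ester

The source may report more compounds than this note shows. Statements on the series, on what has been measured and on what is new or still open speak of the compounds shown alone.

Of the compounds shown here, two have been measured in an ADME assay on S9 fraction from liver (Rattus norvegicus) for metabolic stability, read by LC-MS, using NADPH, with a stated time of 30 min; a lower number here means that less of the compound is left, a higher number that more of the compound is left. Compound 1 `CCCCCCCCc1ccc(OC(C)C(=O)Cn2nnc(-c3ccccc3)n2)cc1` gives 40% in this assay. Compound 2 `CCCCCCCCc1ccc(OC(C)C(=O)Cn2nnc(-c3ccc(C(=O)OC)cc3)n2)cc1` carries a methoxycarbonyl on an aromatic carbon where compound 1 carries hydrogen, and in this assay compound 2 gives 62%. Going by the values given here, the one step recorded, a number 22 percentage points higher from compound 1 to compound 2 (beyond the scatter), lies beyond the scatter, so compound 2 stands as the higher of the two numbers, with compound 1 the only neighbour.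

Compound 3 `COC(=O)c1ccc(-c2nnn(CC(=O)C(C)Oc3ccc(Oc4ccc(C(F)(F)F)cc4)cc3)n2)cc1` keeps the methoxycarbonyl of compound 2 but differs at the other end: 4-(trifluoromethyl)phenoxy in place of octyl on an aromatic carbon. Among the compounds with values here, no measured step touches this part of the structure; the single step seen concerns a different position, and the octyl chain was present in both measured compounds. There is therefore no comparison to show in which direction, or how far, this change should move the number in this assay. The expectation for compound 3 is a step of a number 2 percentage points lower from compound 2 to compound 3 (within the scatter), that is, no change beyond the scatter, with wide uncertainty. Compound 3 is estimated at 60%, ranging from 30% to 85%.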

Compound 3, percent of the compound remaining: 15%
Beside the measured number, compound 3's estimate is 45 percentage points above it; measured number below the stated range.
By their numbers in this assay, from the lowest: compound 3; then compound 1; then compound 2.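

The octyl chain was shared by the first two compounds, so its influence could not be seen, but this position clearly matters for the read-out. In this assay, 4-(trifluoromethyl)phenoxy in place of octyl gives a number 47 percentage points lower from compound 2 to compound 3 (beyond the scatter) even though the methoxycarbonyl stays, so that group alone does not keep the number high. This large fall runs opposite to the rise of a number 22 percentage points higher from compound 1 to compound 2 (beyond the scatter) and is greater in size, but nothing measured here explains the fall.

With only one replacement shown at this position, it remains open whether the fall follows the entering aromatic ring, its linking oxygen or its trifluoromethyl group, and plain phenoxy or a shorter chain such as butyl could help separate these possibilities. From the compounds shown here alone, it is also open whether the methoxycarbonyl would still raise the number with 4-(trifluoromethyl)phenoxy in place, a question that could be tested by putting hydrogen or a carboxylic acid at the methoxycarbonyl position while keeping the rest of compound 3 unchanged.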